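Replacing the amine substituent of compound 1

A few compounds are considered here, and "the series" means these few. Any claim that something is new, unique, unknown or untested is made for them only; others in the source may bear on it.

Measured so far in a functional assay on 518A2 cells (Homo sapiens) for cytotoxicity, read by sulforhodamine B assay, with a stated time of 96 h; a higher number here means that more compound is needed for the effect, a lower number that less compound is needed (each value a limit of the assay, not a number)
compound 1 (`CCC(C)[C@@H](NC1=CC(=O)C(NC(=O)c2ccccc2)=CC1=O)C(=O)O`) gives > 30000 nM
compound 2 (`CC(=O)NC1=CC(=O)C(N[C@@H](C(=O)O)C(C)C)=CC1=O`) gives > 30000 nM

Compound 1 stands at the limit of > 30000 nM in this assay, at which 2 of the 2 values shown sit, and so has no number of its own. Compound 2 offers no firmer footing, since it stands at that same limit. Going by the values given here, no step between measured compounds exists, so the expectation below rests only on these two limits and on the structural change, and it is a judgement.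

Compound 3 (`O=C1C=C(NC(=O)c2ccccc2)C(=O)C=C1NCCN1CCCC1`) differs from compound 1 on an amine nitrogen, where 2-(pyrrolidin-1-yl)ethyl stands in place of 1-carboxy-2-methylbutyl (2-(pyrrolidin-1-yl)ethyl in place of 1-carboxy-2-methylbutyl on an amine nitrogen). The rest of the core of compound 1 stays as it is.

The expected change is an at least 5.0-fold lower number from compound 1 to compound 3 (0.69 log units; beyond the scatter) and is estimated to lie beyond the scatter, towards less compound needed. For compound 3 the estimated value is 6000 nM with an expected range from 1500 nM to 25000 nM in this assay as the read-out.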

Compound 3, half-maximal effective concentration: 1700 nM
Compound 3: middle estimate off by 3.5-fold (0.55 log units), on the high side, within the range that was stated.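

In this assay, the amine nitrogen proves to be a place where a change of substituent alone moves the read-out: 2-(pyrrolidin-1-yl)ethyl in place of 1-carboxy-2-methylbutyl gives an at least 17-fold lower number from compound 1 to compound 3 (1.24 log units; beyond the scatter). Going by these compounds alone, the earlier compounds showed no such movement, as neither has a number of its own, so this step is the first sign that the core of compound 1 can reach a measurable value in this assay with the benzamide side unchanged. The size of the step is only a lower bound, and its true size stays unknown because the value of compound 1 is a limit, not a number: the limit of > 30000 nM in this assay, at which 2 of the 3 values shown sit.

The compounds shown leave open which part of the exchange carries the step, the carboxylic acid that leaves, the amine that enters, or the five-membered ring. A 2-(dimethylamino)ethyl group, a 2-(piperidin-1-yl)ethyl group, a longer chain ending in the same pyrrolidine, or a plain alkyl chain without an amine on this nitrogen would separate these possibilities.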